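From Benzoyl to Phenylsulfonyl: An Expected Growth Inhibition Value

A few compounds are considered here, and "the series" means these few. Any claim that something is new, unique, unknown or untested is made for them only; others in the source may bear on it.

Of the compounds shown here, three built on a shared core have been tested in a functional assay on T47D cells (Homo sapiens) for inhibition, read by sulforhodamine B assay, with a stated time of 48 h; a higher number here means a weaker inhibitor of growth, a lower number a stronger inhibitor of growth. Compound 1 `N#C/C(=C\c1c(-c2ccccc2)[nH]c2ccccc12)C(=O)c1ccccc1` gives 5300 nM, the highest number among the three. Compound 2 `CCOC(=O)C(=Cc1c(-c2ccccc2)[nH]c2ccccc12)C(=O)OCC` gives 2700 nM, a number within the usual scatter of that of compound 1, so the two cannot be told apart. Compound 3 `COc1ccc(-c2[nH]c3ccc(OC)cc3c2C=C(C#N)C#N)cc1` gives 2600 nM, a number that lies just beyond the scatter from compound 1, so compound 3 appears the stronger inhibitor of growth of these two.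

Compound 4 `N#C/C(=C\c1c(-c2ccccc2)[nH]c2ccccc12)S(=O)(=O)c1ccccc1` has not yet been measured. It differs from compound 1 in one place: phenylsulfonyl in place of benzoyl on a double-bonded chain carbon bound to a double-bonded chain carbon and a triple-bonded carbon. Among the measured compounds shown here, no pair of measured compounds shows what such a change does here, so the expectation rests on compound 1 alone, which gives 5300 nM in this assay. One expects a step of modest size, a 1.3-fold lower number from compound 1 to compound 4 (0.12 log units; within the scatter), most likely toward a somewhat lower number but not clearly beyond the scatter. For compound 4 the estimated value in this assay is 4000 nM, with a range from 1300 nM to 12000 nM.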

Compound 4, concentration for 50% growth inhibition: 3800 nM
Beside the measured number, compound 4's estimate is 1.1-fold (0.02 log units) above it; low and high end bracket the measured number.
By their numbers in this assay, from the lowest: compounds 3, 2, 4 and 1 (each within the scatter of the next, the first and the last beyond it).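

In this assay, among the compounds shown here, phenylsulfonyl in place of benzoyl gives a 1.4-fold lower number from compound 1 to compound 4 (0.14 log units; within the scatter), the first step that can be read at this position, on a double-bonded chain carbon bound to a double-bonded chain carbon and a triple-bonded carbon. The two compounds therefore cannot be told apart here, even though the entering group brings sulfur, 2 double bonds outside aromatic rings and 2 hydrogen-bond acceptors where benzoyl has 1 of each. Nothing available bears on why the exchange leaves the number within the scatter.

As far as these compounds go, whether an amine, a carboxylic acid or a longer chain at this position would move the number beyond the scatter remains open. Also open, from the compounds shown here alone, is whether the same exchange would give a similar step on a core carrying methoxy groups, as in compound 3.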